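This account rests on a few compounds, and the source may have more. Where it says the series, first, only, none or still open, it means among the compounds named here.

Working notes on the series.

Three compounds have numbers in an assay on isolated protein for inhibition of histone deacetylase 8 (Homo sapiens), read by fluorescence, with a stated time of 90 min; a lower number here means a stronger inhibitor, a higher number a weaker inhibitor. Compound 1 `COc1ccc(C(=O)NO)cc1C(=O)Nc1ccc2c(c1)cc(C)c(=O)n2C` gives 65 nM in this assay. Compound 2 `COc1ccc(C(=O)NO)cc1S(=O)(=O)Nc1ccc2c(c1)cc(C)c(=O)n2C`, which carries a sulfonamide linker in place of the amide, gives 443 nM in this assay. Compound 3 `Cc1cc2cc(NCc3cc(C(=O)NO)ccc3Cl)ccc2n(C)c1=O`, which carries an aminomethyl linker and a chloro group, gives 3190 nM in this assay. Compound 1 stands lowest of the three; its gap to compound 2 lies beyond the usual scatter, and its gap to compound 3 lies further beyond it, so compound 1 is the strongest inhibitor among the measured compounds.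

Compound 4 `Cc1cc2cc(NC(=O)c3cc(C(=O)NO)ccc3Cl)ccc2n(C)c1=O` has not been measured. It differs from compound 1 in one place: chloro in place of methoxy on an aromatic carbon. Among the measured compounds shown here, no single-change step between measured compounds exists for this swap, so no measured precedent sets its size. Compound 3 holds the chloro group but also a different linker, so its value of 3190 nM cannot be read as the effect of the chloro group alone.

For compound 4 in this assay a modest loss against compound 1 is expected, the step from compound 1 to compound 4 being estimated at a 1.8-fold higher number from compound 1 to compound 4 (0.27 log units; within the scatter). Compound 4 is estimated at 120 nM, with a range from 40 nM to 400 nM.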

Compound 4, half-maximal inhibitory concentration: 113 nM
The estimate for compound 4 lay 1.1-fold (0.03 log units) above the measured number, and the stated range covers the measured number.
By their numbers in this assay, from the lowest: compounds 1 and 4 (each within the scatter of the next); then compound 2; then compound 3.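

In this assay, among the compounds shown here, chloro in place of methoxy on this aromatic carbon, ortho to a large group and para to a hydroxycarbamoyl group, gives a 1.7-fold higher number from compound 1 to compound 4 (0.24 log units; within the scatter), so the amide series keeps its number across this swap even though the hydrogen-bond acceptor counted on methoxy has no counterpart on chloro. For the compounds shown here, with the chloro group held, compound 4 gives 113 nM and compound 3 gives 3190 nM, which puts the amide and aminomethyl linkers side by side for the first time and shows the higher number of compound 3 going with the linker, not with the chloro group. Nothing at hand bears on why methoxy and chloro give such close numbers at this position.

Still open, on these data alone, is how far this tolerance reaches: an amine, a carboxylic acid or a longer alkoxy chain at the same carbon could behave quite differently from these two groups. As far as these compounds go, it is also open whether chloro and methoxy stay equivalent with the sulfonamide linker, since the values shown compare the two groups only with the amide linker in place.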